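The compounds below may be only part of what the source reports. "The series", "measured", "known", "first", "only" and "open" are said of these compounds alone.

Working notes on the azetidinone series. The shared core carries an aryl group on the saturated ring and a second aryl group on the ring nitrogen; compound 1 `COc1ccc([C@H]2[C@H](O)C(=O)N2c2cc(OC)cc(OC)c2)cc1` and compound 3 `COc1ccc([C@@H]2[C@H](O)C(=O)N2c2cc(OC)c(OC)c(OC)c2)cc1[N+](=O)[O-]` vary both aryl groups, while compound 2 `COc1ccc(N2C(=O)[C@@H](O)[C@@H]2c2cc(OC)c(OC)c(OC)c2)cc1O` and compound 4 `COc1ccc(N2C(=O)[C@@H](O)[C@H]2c2cc(OC)c(OC)c(OC)c2)cc1O` share a single substitution pattern. In a functional assay on HuTu80 cells (Homo sapiens) for antiproliferative activity, read by MTT assay, with a stated time of 72 h (a lower number here means a stronger inhibitor, a higher number a weaker inhibitor), compound 2 gives 406 nM. Compound 3 gives 529 nM in this assay, a number that sits within the scatter of the value for compound 2, so no order between the two is claimed. Compound 1 returns several entries in this assay, 9.05 nM; 8.02 nM; 83.6 nM (3 entries), and the spread among them the several entries of compound 1 in this assay, 9.05 nM; 8.02 nM; 83.6 nM (3 entries) is itself a caution on how far any single number in this series may be trusted.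

Compound 4 is not yet measured in this assay. Compound 4 differs from compound 2 in nothing but configuration as drawn: the two compounds have the same atoms and bonds and differ only in configuration as drawn: 1 of 2 stereo elements differ; a stereocentre at a saturated ring carbon is drawn S in compound 2 and R in compound 4. For the measured compounds named here, no measured pair isolates such an inversion, so the size of the step can only be expected, not read off. A step toward a higher number is expected here, of moderate size, and the estimated step from compound 2 to compound 4 is a 3.0-fold higher number from compound 2 to compound 4 (0.47 log units; beyond the scatter). In this assay compound 4 is expected to give about 1200 nM, with a range from 250 nM to 6000 nM.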

Compound 4, half-maximal inhibitory concentration: 2550 nM
Estimate against measurement, compound 4: 2.1-fold (0.33 log units) below, and the stated range covers the measured number.
By their numbers in this assay, from the lowest: compounds 2 and 3 (each within the scatter of the next); then compound 4.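

In this assay, for the compounds shown here, inverting the stereocentre at a saturated ring carbon, with atoms and bonds unchanged, gives a 6.3-fold higher number from compound 2 to compound 4 (0.80 log units; beyond the scatter), so the drawn configuration at this carbon separates two compounds by more than the scatter, which no earlier pair could show. The step can be assigned to this inversion alone because nothing else changes: the fact that compounds 2 and 4 differ only in the configuration as drawn. Its exact size is best held loosely, since it rests on one pair with one entry per compound and repeated entries in this series can spread widely: the several entries of compound 1 in this assay, 9.05 nM; 8.02 nM; 83.6 nM (3 entries).

The compounds shown leave open whether the same inversion gives a step of similar direction and size on other aryl patterns, such as those of compound 1 and compound 3, and what inverting the second stereo element, alone or together with the first, would do. Also open, on these data alone, is how the number in this assay responds when the ring hydroxyl is replaced by an amine or the hydroxyl on the aryl group by a carboxylic acid, with the configuration of compound 2 held fixed.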